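The compounds below may be only part of what the source reports. "The series", "measured", "known", "first", "only" and "open" are said of these compounds alone.

For the measured compounds named here, compound 3 `C/C(=N\OC(Cc1ccccc1)c1ccc(OCc2ccc3ccccc3n2)cc1)C(=O)O` sits second highest of the three numbers so far in a functional assay for inhibition of Polyunsaturated fatty acid 5-lipoxygenase (Homo sapiens); on this read-out lower numbers stand for stronger inhibition and higher numbers for weaker inhibition. Compound 3 gives 30 nM. Its nearest neighbour is compound 2 `C/C(=N\OC(c1ccc(OCc2ccc3ccccc3n2)cc1)C1CCCC1)C(=O)O`, which gives 16 nM, and the gap a 1.9-fold higher number from compound 2 to compound 3 (0.27 log units; within the scatter) lies within the scatter. Furthest is compound 1 `C=CCC(O/N=C(\C)C(=O)O)c1ccc(OCc2ccc3ccccc3n2)cc1`, which gives 142 nM, and the step of a 4.7-fold lower number from compound 1 to compound 3 (0.68 log units; beyond the scatter) lies beyond it.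

Compound 4 `C/C(=N\OC(CC(C)(C)c1ccccc1)c1ccc(OCc2ccc3ccccc3n2)cc1)C(=O)O` differs from compound 3 in one place: 1-methyl-1-phenylethyl in place of phenyl on a saturated chain carbon, two bonds along the chain from an aromatic carbon and an oxygen.

Going by the values given here, two measured steps bear on this change. The step of a 4.7-fold lower number from compound 1 to compound 3 (0.68 log units; beyond the scatter) shows that enlarging the substituent on this saturated chain carbon from vinyl to phenyl lowered the number; the step of an 8.9-fold lower number from compound 1 to compound 2 (0.95 log units; beyond the scatter) shows a similar lowering when allyl gave way to cyclopentyl on the neighbouring carbon; and the step of a 1.9-fold higher number from compound 2 to compound 3 (0.27 log units; within the scatter) shows that cyclopentyl and benzyl, both larger than the groups in compound 1, give numbers within the scatter of each other. On that basis, adding two methyl groups to reach 1-methyl-1-phenylethyl is expected to leave the number near that of compound 3, with at most a small drop.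

Compound 4 is therefore expected to give 22 nM, with a range from 7 nM to 70 nM. The expected step is a 1.4-fold lower number from compound 3 to compound 4 (0.13 log units; within the scatter).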

Compound 4, half-maximal inhibitory concentration: 22 nM
Compound 4: middle estimate and measured number agree at the digits printed, within the range that was stated.
By their numbers in this assay, from the lowest: compounds 2, 4 and 3 (each within the scatter of the next); then compound 1.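

In this assay, the step of a 1.4-fold lower number from compound 3 to compound 4 (0.13 log units; within the scatter) shows that this position accepts 1-methyl-1-phenylethyl in place of phenyl, a growth from 6 to 9 heavy atoms, with no change that stands clear of the scatter, so the two added methyl groups are tolerated here. The step of a 1.4-fold higher number from compound 2 to compound 4 (0.14 log units; within the scatter) places 2-methyl-2-phenylpropyl level with cyclopentyl, while the step of a 6.5-fold lower number from compound 1 to compound 4 (0.81 log units; beyond the scatter) keeps the new group clearly apart from the allyl group, so the larger groups seen so far, both with and without an aromatic ring, form one set separate from allyl. Nothing given here accounts for why these larger groups read alike.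

The compounds shown leave open how far this tolerance extends, for instance to a longer chain between the saturated carbon and the phenyl ring, or to a phenyl ring carrying a methoxy group or a chlorine. They also leave open whether an amine or a hydroxyl group on this chain would keep the number in the same range.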